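The source may report more compounds than this note shows. Statements on the series, on what has been measured and on what is new or still open speak of the compounds shown alone.

Compound 1, `COc1cc(-c2cc(/C=C/C(=O)c3ccc(N)cc3)[nH]n2)cc(OC)c1OC`, is the point of departure. In a functional assay on Hs-578T cells (Homo sapiens) for cytotoxicity, read by sulforhodamine B assay, with a stated time of 48 h, tested at 0.01 uM (on this read-out lower numbers stand for a stronger effect and higher numbers for a weaker effect at the one concentration tested), compound 1 gives 95%. Two other compounds have been read in this assay: compound 2, `COc1ccc(-c2cc(/C=C/C(=O)c3ccc(OC)c(OC)c3)[nH]n2)cc1`, which gives 96%, and compound 3, `COc1cc(-c2cc(/C=C/C(=O)c3ccc(Cl)c(Cl)c3)[nH]n2)cc(OC)c1OC`, which gives 98%. Among these three numbers, compound 1 sits at the low end, yet its distance to compound 2 and to compound 3 is in each case within the scatter, so the three stand together. Going by the values given here, the one measured step that changes a single place, a number 3 percentage points higher from compound 1 to compound 3 (within the scatter), is likewise within the scatter.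

Compound 4 is `COc1ccc(-c2cc(/C=C/C(=O)c3ccc(N)cc3)[nH]n2)cc1OC`. It differs from compound 1 by hydrogen in place of methoxy on an aromatic carbon. Among the compounds with values here, no measured step in this set touches this place; the only step on record, from compound 1 to compound 3, alters the group on the carbonyl carbon instead and stays within the scatter. Within the data shown here, with all three measured numbers lying close together and the sole measured change producing no effect beyond the scatter, compound 4 is expected to show no change at the digits printed from compound 1 to compound 4 (within the scatter), that is, nothing beyond the scatter. The estimate for compound 4 in this assay is therefore 95%, with a range from 85% to 102%.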

Compound 4, a percentage reported as activity, at one concentration (the size of the read-out at that concentration, not a potency): 98%
Beside the measured number, compound 4's estimate is 3 percentage points below it; the measured number falls inside the stated range.
By their numbers in this assay, from the lowest: compounds 1, 2, 3 and 4 (each within the scatter of the next).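

Hydrogen in place of methoxy gave a number 3 percentage points higher from compound 1 to compound 4 (within the scatter) in this assay. Going by these compounds alone, this is the first reading at this position, an aromatic carbon ortho to a methoxy group and meta to a large group, as the earlier step changed only the group on the carbonyl carbon; at the one concentration tested, removing this methoxy moved the read-out no further than the scatter. No evidence on these compounds speaks to the reason for this result.

With all four compounds lying within the scatter of one another at this single concentration, the data cannot show whether this position matters at all under conditions where the compounds have a clear effect. From the compounds shown here alone, it also remains open whether a different group on this carbon, such as a hydroxyl, a fluorine, an amine or a longer alkoxy chain, would read differently, and whether the same change would give the same result with the 3,4-dichlorophenyl group on the carbonyl carbon.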